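A few compounds are considered here, and "the series" means these few. Any claim that something is new, unique, unknown or untested is made for them only; others in the source may bear on it.

Measured so far:
compound 1, `Cn1cnc2c(Sc3ccc(F)cc3)ncnc21`: 0%
compound 2, `Cn1c(-c2ccccc2)nc2c(Sc3ccccc3)ncnc21`: 42%

Of the compounds shown here, two have been measured in an assay on isolated protein for inhibition of RAC-alpha serine/threonine-protein kinase (Homo sapiens), tested at 30 uM; a higher number here means more inhibition at the concentration tested (going by the name of the read-out), a lower number less inhibition. Compound 1 `Cn1cnc2c(Sc3ccc(F)cc3)ncnc21` gives 0% there, no inhibition at the concentration used. Compound 2 `Cn1c(-c2ccccc2)nc2c(Sc3ccccc3)ncnc21` gives 42% in this assay, the higher of the two numbers and beyond the scatter from compound 1. The two structures differ in more than one place, so their values are compared only as numbers, and nothing is said here about which change carries the difference.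

Compound 3 `Cn1c(-c2ccccc2)nc2c(Sc3ccc(F)cc3)ncnc21` is not yet measured. It is compound 2 with one change: fluoro in place of hydrogen on an aromatic carbon. Among the measured compounds shown here, the same substituent is present in compound 1, but there without the phenyl group of compound 2, so no single step in the data shows what this change alone does. A small step is expected, in either direction or none beyond the scatter; the estimated step is a number 4 percentage points lower from compound 2 to compound 3 (within the scatter). Compound 3 is therefore expected to give about 38% in this assay, with a range from 15% to 60%.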

Compound 3, a percentage reported as inhibition, at one concentration (the size of the read-out at that concentration, not a potency): 29%
Compound 3: middle estimate off by 9 percentage points, on the high side; the range from low to high includes it.
By their numbers in this assay, from the lowest: compound 1; then compound 3; then compound 2.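

Fluoro in place of hydrogen on the aromatic carbon, the change from phenylsulfanyl to (4-fluorophenyl)sulfanyl, now has a single-step reading of its own in this assay, and that reading is a number 13 percentage points lower from compound 2 to compound 3 (beyond the scatter), a modest loss rather than a neutral swap. Among the compounds shown here, the same set of compounds also gives the first single-step reading for adding the phenyl group to the core of compound 1: with the fluoro kept in place, this assay shows a number 29 percentage points higher from compound 1 to compound 3 (beyond the scatter), so the two changes move the read-out in opposite directions. No measurement is available that accounts for the direction or size of either step.

The compounds shown leave open how a chloro, a methoxy or an amine at this same place on the phenylsulfanyl ring would compare with hydrogen and fluoro, the only two substituents seen there. They also leave open what the phenyl step would be with hydrogen instead of fluoro on that ring, and whether a longer chain or a carboxylic acid in place of the phenyl group would bring any such rise.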